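A Ring Swap at the End of the Side Chain

The source may hold more compounds than are shown below. What is called first, only, known or untested is meant among the compounds shown, and "the series" means these compounds.

Three compounds share one core and differ only in the group on an amide-type nitrogen. Compound 1 `CCN(CC)CCNC(=O)Nc1nc2ccc(-c3cnc(OC)c(NS(=O)(=O)c4ccc(F)cc4)c3)cc2s1` gives 300 nM in a functional assay on HCT-116 cells (Homo sapiens) for antiproliferative activity, read by MTT assay, with a stated time of 72 h; a lower number here means a stronger inhibitor, a higher number a weaker inhibitor; compound 2 `COc1ncc(-c2ccc3nc(NC(=O)NC4CC4)sc3c2)cc1NS(=O)(=O)c1ccc(F)cc1` gives 470 nM; compound 3 `COc1ncc(-c2ccc3nc(NC(=O)NCCN4CCCCC4)sc3c2)cc1NS(=O)(=O)c1ccc(F)cc1` gives 610 nM, the highest of the three numbers, though its gap to compound 2 is within the scatter. Compound 4 `COc1ncc(-c2ccc3nc(NC(=O)NCCN4CCN(C)CC4)sc3c2)cc1NS(=O)(=O)c1ccc(F)cc1` is not yet measured. Its change from compound 3 is 4-methylpiperazin-1-yl in place of piperidin-1-yl on a saturated chain carbon, two bonds along the chain from an amide-type nitrogen. The closest measured step, a 2.0-fold higher number from compound 1 to compound 3 (0.31 log units; beyond the scatter), also altered the group on that chain carbon and moved the number only modestly, while a 1.6-fold higher number from compound 1 to compound 2 (0.19 log units; within the scatter) and a 1.3-fold higher number from compound 2 to compound 3 (0.11 log units; within the scatter) stayed within the scatter. For compound 4 a step of similar small size, or none beyond the scatter, is therefore expected, a 1.2-fold lower number from compound 3 to compound 4 (0.09 log units; within the scatter). Compound 4 is estimated at 500 nM, within 250 nM to 1000 nM.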

Compound 4, half-maximal inhibitory concentration: 540 nM
Beside the measured number, compound 4's estimate is 1.1-fold (0.03 log units) below it; measured number inside the range.
By their numbers in this assay, from the lowest: compounds 1, 2, 4 and 3 (each within the scatter of the next, the first and the last beyond it).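

In this assay, a 1.1-fold lower number from compound 3 to compound 4 (0.05 log units; within the scatter) shows that this place on the side chain accepts 4-methylpiperazin-1-yl in place of piperidin-1-yl with no change beyond the scatter. The other two comparisons, a 1.1-fold higher number from compound 2 to compound 4 (0.06 log units; within the scatter) and a 1.8-fold higher number from compound 1 to compound 4 (0.26 log units; within the scatter), also stay within the scatter, so compound 4 is not separated from compound 1, whereas compound 3 is. A morpholin-4-yl ring at this place, or a longer chain carrying 4-methylpiperazin-1-yl, remains an open question. Nothing available here explains why these steps are so small.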